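From Compound 3 to Its Fluoro Analogue

The source may hold more compounds than are shown below. What is called first, only, known or untested is meant among the compounds shown, and "the series" means these compounds.

Measured in a functional assay on MCF7 cells (Homo sapiens) for cytotoxicity, read by MTT assay, with a stated time of 96 h; a higher number here means a weaker inhibitor, a lower number a stronger inhibitor:
- Compound 1 `COc1cc(C(=O)c2cn(-c3ccccc3[N+](=O)[O-])cc2-c2ccccc2)cc(OC)c1OC` gives 5000 nM
- Compound 2 `COc1ccccc1-n1cc(C(=O)c2cc(OC)c(OC)c(OC)c2)c(-c2ccccc2)c1` gives 150 nM
- Compound 3 `COc1cc(C(=O)c2cn(-c3ccc(N)cc3)cc2-c2ccccc2)cc(OC)c1OC` gives 35 nM

Compound 3 has the lowest number of the three in this assay, so it is the strongest inhibitor measured so far. Compound 4 `COc1cc(C(=O)c2cn(-c3ccc(N)cc3)cc2-c2ccccc2F)cc(OC)c1OC` differs from it by fluoro in place of hydrogen on an aromatic carbon, turning phenyl into 2-fluorophenyl (fluoro in place of hydrogen on an aromatic carbon).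

Among the measured compounds shown here, no measured step makes this change. All three alter the aryl group on the aromatic nitrogen, and they are the nearest evidence available: a 33-fold lower number from compound 1 to compound 2 (1.52 log units; beyond the scatter), a 140-fold lower number from compound 1 to compound 3 (2.15 log units; beyond the scatter) and a 4.3-fold lower number from compound 2 to compound 3 (0.63 log units; beyond the scatter). Their sizes therefore carry over poorly to a single fluoro, and they give no direction for it. A change beyond the scatter is not expected, in either direction. The estimated step is a 1.1-fold higher number from compound 3 to compound 4 (0.06 log units; within the scatter). For compound 4 the expected value is 40 nM, with an estimated range from 12 nM to 130 nM.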

Compound 4, half-maximal inhibitory concentration: 28 nM
Beside the measured number, compound 4's estimate is 1.4-fold (0.15 log units) above it, and the stated range covers the measured number.
By their numbers in this assay, from the lowest: compounds 4 and 3 (each within the scatter of the next); then compound 2; then compound 1.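

In this assay, fluoro in place of hydrogen, ortho to a large group, gives a 1.3-fold lower number from compound 3 to compound 4 (0.10 log units; within the scatter). Among the compounds shown here, every earlier step altered the aryl group on the aromatic nitrogen, so this is the first reading from the phenyl group, and it shows that with 4-aminophenyl held constant, this phenyl takes a single fluoro without a change beyond the scatter. No measurement of any property of these compounds bears on this result.

As far as these compounds go, whether a chloro, a trifluoromethyl or a hydroxyl in the same place would also stay within the scatter remains open, as does the effect of a fluoro elsewhere on that ring. From the compounds shown here alone, it is also open whether the fluoro would behave the same way with 2-methoxyphenyl or 2-nitrophenyl on the aromatic nitrogen.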